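The source may report more compounds than this note shows. Statements on the series, on what has been measured and on what is new or still open speak of the compounds shown alone.

Measured in a functional assay on ACHN cells (Homo sapiens) for antiproliferative activity, read by sulforhodamine B assay; a higher number here means a weaker inhibitor of growth, a lower number a stronger inhibitor of growth:
- Compound 1 `CCCCOc1cccc(O)c1C(=O)/C=C/c1ccc(O)cc1`: > 30000 nM (a limit)
- Compound 2 `O=C(/C=C/c1ccc(O)cc1)c1c(O)cccc1OCc1ccccc1`: > 30000 nM (a limit)

Compound 2 gives only a limit, > 30000 nM, and not a number. Compound 3 `O=C(/C=C/c1ccc(O)cc1)c1c(O)cccc1OCCC1CCCC1` carries cyclopentylmethyl in place of phenyl on a saturated chain carbon bound to an oxygen on an aromatic ring. Going by the values given here, the only measured step bearing on this change is a step that the two limits leave unreadable from compound 1 to compound 2, so it offers no size to carry over. No shift in either direction can therefore be forecast in this assay, and another limit is likely. The estimated step is a number no higher from compound 2 to compound 3 (the limit leaves the size open). Compound 3 is expected at about 30000 nM, with an estimated range of 12000 nM to 60000 nM.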

Compound 3, concentration for 50% growth inhibition: 3400 nM
Beside the measured number, compound 3's estimate is 8.8-fold (0.95 log units) above it; measured number below the stated range.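

In this assay, going by these compounds alone, compound 3 is the first of the three with a number and not a limit, showing that growth inhibition can be read with a change at this position. Cyclopentylmethyl in place of phenyl gives an at least 8.8-fold lower number from compound 2 to compound 3 (0.94 log units; beyond the scatter) and cyclopentyl in place of ethyl gives an at least 8.8-fold lower number from compound 1 to compound 3 (0.94 log units; beyond the scatter) on the same chain. Both steps are open-ended, as each starts from a limit: the limit of > 30000 nM in this assay, at which 2 of the 3 values shown sit.

On these data alone, whether the gain depends on the saturated ring or on the length of chain carrying it remains open. A cyclohexyl ring, a longer chain or an amine at this position could separate these possibilities.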